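Methoxy on the benzothiazole of a weak porcupine inhibitor

A few compounds are considered here, and "the series" means these few. Any claim that something is new, unique, unknown or untested is made for them only; others in the source may bear on it.

Measured compounds:
compound 1 `COc1ccccc1-n1nc(C(=O)NCC(=O)Nc2nc3ccccc3s2)c2ccccc2c1=O` — 10000 nM
compound 2 `O=C(CNC(=O)c1nn(-c2ccc(F)cc2)c(=O)c2ccccc12)Nc1nc2ccccc2s1` — > 25000 nM
compound 3 `O=C(CNC(=O)c1nn(-c2ccccc2)c(=O)c2ccccc12)Nc1nc2ccccc2s1` — 2600 nM

Three compounds share one core and differ only in the aryl group on the ring nitrogen. In an assay on L cells for inhibition of Protein-serine O-palmitoleoyltransferase porcupine (Mus musculus), read by reporter gene assay, with a stated time of 24 h (a higher number here means that more compound is needed for the effect, a lower number that less compound is needed), compound 1 gives 10000 nM, and compound 3 gives 2600 nM. For compound 2 this assay reports only a limit, > 25000 nM, which is the limit itself the limit of > 25000 nM in this assay, at which 1 of the 3 values shown sits, and not a number. The steps of an at least 2.5-fold higher number from compound 1 to compound 2 (0.39 log units; beyond the scatter), a 3.8-fold lower number from compound 1 to compound 3 (0.59 log units; beyond the scatter) and an at least 9.6-fold lower number from compound 2 to compound 3 (0.98 log units; beyond the scatter) all concern the aryl group on the nitrogen.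

Compound 4 `COc1ccc2nc(NC(=O)CNC(=O)c3nn(-c4ccc(F)cc4)c(=O)c4ccccc34)sc2c1` keeps the 4-fluorophenyl of compound 2 and changes the other end: methoxy in place of hydrogen on an aromatic carbon. Within the data shown here, none of the measured steps touches this part of the molecule, so they give no direct guidance on its size or direction. Starting from a limit, the expected step of an at least 1.2-fold lower number from compound 2 to compound 4 (0.09 log units; that floor lies within the scatter) is therefore written with low confidence. Compound 4 is estimated at 20000 nM, within 4000 nM to 80000 nM, with a real chance that this assay again reports only a limit.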

Compound 4, half-maximal effective concentration: 90 nM
Compound 4: middle estimate off by 220-fold (2.35 log units), on the high side; measured number outside the range, below it.
By their numbers in this assay, from the lowest: compound 4; then compound 3; then compound 1. At a limit, above all of these: compound 2.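

Among these compounds, on the 1,3-benzothiazol-2-yl end, which no earlier step touched, methoxy in place of hydrogen gives an at least 270-fold lower number from compound 2 to compound 4 (2.44 log units; beyond the scatter) in this assay, so a single small group at this position can produce a large step. Compound 2 sits at a limit, > 25000 nM, so this step is a floor and not a measured size. Methoxy on the aryl group of compound 1 and methoxy on the 6-methoxy-1,3-benzothiazol-2-yl group of compound 4 read in opposite directions, so the outcome of this change depends on where it is made: the same change on two cores in this assay, a 3.8-fold lower number (0.59 log units; beyond the scatter) from compound 1 to compound 3 and an at least 270-fold higher number (2.44 log units; beyond the scatter) from compound 4 to compound 2, at least 1000-fold (3.02 log units) apart, beyond the scatter of two such steps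

As far as these compounds go, whether the step would hold with the phenyl of compound 3 in place of the 4-fluorophenyl stays open. Also open, from the compounds shown here alone, is whether ethoxy, hydroxy or an amine in the same place would give a comparable number.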